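This account rests on a few compounds, and the source may have more. Where it says the series, first, only, none or still open, it means among the compounds named here.

In an assay on isolated protein for inhibition of sodium channel protein type 4 subunit alpha (Homo sapiens), read by electrophysiology, with a stated time of 4 min (a higher number here means a weaker inhibitor, a lower number a stronger inhibitor), compound 1 `CC(C)(C)OC(=O)n1cc(-c2ccc(NC(=O)c3ccco3)cc2)nc1N` gives > 30000 nM, which is a limit of the assay rather than a number. Compound 2 `CC(C)(C)OC(=O)n1cc(-c2ccc(NC(=O)[C@@H]3CCCN3)cc2)nc1N` carries a pyrrolidin-2-yl in place of the furan-2-yl of compound 1 on a carbonyl carbon. In this assay compound 2 gives > 30000 nM, again a limit and not a number. The step that the two limits leave unreadable from compound 1 to compound 2 therefore cannot be read. Both values sit at the limit of > 30000 nM in this assay, at which 2 of the 2 values shown sit, so compound 2 stands at the edge of what this assay reports, with no inhibition measured within its range. Compound 3 `CC(C)(C)OC(=O)n1cc(-c2ccc(NC(=O)[C@H]3CCCN3)cc2)nc1N` is the counterpart of compound 2 with a single change: the two compounds have the same atoms and bonds and differ only in configuration as drawn: 1 of 1 stereo elements differ; a stereocentre at a saturated ring carbon is drawn S in compound 2 and R in compound 3. For the measured compounds named here, no measured step involves a change of configuration alone, and the one measured step, from compound 1 to compound 2, is itself unreadable, so there is no basis to expect a move beyond the scatter. Compound 3 is therefore expected to stay at the limit, with an estimated 30000 nM in the range 10000 nM to 100000 nM. The expected step of a number no higher from compound 2 to compound 3 (the limit leaves the size open) is none beyond the scatter.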

Compound 3, half-maximal inhibitory concentration: > 30000 nM
Compound 3 gave a limit, no number (the forecaster's own chance of this, stated with the estimate: 85%); the middle value sits exactly at the limit.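

In this assay the steps among compound 1, compound 2 and compound 3 cannot be read, because each value is a limit and not a number: the limit of > 30000 nM in this assay, at which 3 of the 3 values shown sit.

The compounds shown leave open whether pyrrolidin-2-yl in place of furan-2-yl, or the configuration drawn at the saturated ring carbon, makes any difference to inhibition.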